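The compounds below may be only part of what the source reports. "The series", "measured", "known", "first", "only" and "open" are said of these compounds alone.

In a physicochemical assay for solubility, read by HPLC, in phosphate buffer, with a stated time of 24 h, at pH 7.4, tested at 100 uM (a lower number here means a less soluble compound, a higher number a more soluble compound), three compounds have been measured so far. Compound 1 `COc1ccc(Nc2c(NC(C)CCCCC(=O)NO)c(=O)c2=O)cc1` gives 85000000 nM, compound 2 `CC(CCCCC(=O)NO)Nc1c(Nc2ccc(C(F)(F)F)cc2)c(=O)c1=O` gives 30000000 nM, and compound 3 `CC(C)(CCCCC(=O)NO)Nc1c(Nc2ccc(C(F)(F)F)cc2)c(=O)c1=O` gives 36000000 nM. Compound 3 therefore lies within the scatter of compound 2, and the value of compound 1 stands higher than either of them.

The next compound, compound 4 `COc1ccc(Nc2c(NC(C)(C)CCCCC(=O)NO)c(=O)c2=O)cc1`, differs from compound 3 as follows: methoxy in place of trifluoromethyl on an aromatic carbon. This is methoxy in place of trifluoromethyl on an aromatic carbon. Among the measured compounds shown here, two measured steps bear on it. The reverse exchange appears as a 2.8-fold lower number from compound 1 to compound 2 (0.45 log units; beyond the scatter), a modest step. The added methyl appears as a 1.2-fold higher number from compound 2 to compound 3 (0.08 log units; within the scatter), so that step gives no reason to expect a different size on the methylated chain. For the measured compounds named here, only one pair of compounds supports the exchange itself, but reversing it on compound 3 points to a modest rise of similar size in this assay. The expected change is a 2.6-fold higher number from compound 3 to compound 4 (0.42 log units; beyond the scatter). The estimate for compound 4 is 95000000 nM, with an expected range from 45000000 nM to 190000000 nM.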

Compound 4, solubility: 99000000 nM
Compound 4: the middle estimate sits 1.0-fold (0.02 log units) below what was measured; measured number inside the range.
By their numbers in this assay, from the lowest: compounds 2 and 3 (each within the scatter of the next); then compounds 1 and 4 (each within the scatter of the next).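

In this assay, methoxy in place of trifluoromethyl on the aromatic carbon gives a 2.8-fold higher number from compound 3 to compound 4 (0.44 log units; beyond the scatter), a modest step on the methylated chain that mirrors the reverse exchange, a 2.8-fold lower number from compound 1 to compound 2 (0.45 log units; beyond the scatter), so the difference between these two groups now rests on two pairs of compounds and not one. Among the compounds shown here, the added methyl on the chain, earlier seen only with trifluoromethyl on the ring, can now also be read with methoxy there: it gives a 1.2-fold higher number from compound 1 to compound 4 (0.07 log units; within the scatter), and this step, like a 1.2-fold higher number from compound 2 to compound 3 (0.08 log units; within the scatter), lies within the scatter. No measurement shown here accounts for either exchange.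

As far as these compounds go, only methoxy and trifluoromethyl have been seen at this place on the ring, so the reading with an amine or a carboxylic acid there remains open. From the compounds shown here alone, whether the added methyl stays within the scatter alongside such groups also remains open.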